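Notes on the shared core: compound 3 to compound 4

The source may report more compounds than this note shows. Statements on the series, on what has been measured and on what is new or still open speak of the compounds shown alone.

The series keeps one core and varies the group on the aromatic carbon next to the ring nitrogen. Among the measured compounds shown here, in an ADME assay on microsomes from liver (Homo sapiens) for metabolic stability, with a stated time of 60 min, tested at 1 uM (on this read-out higher numbers stand for a more stable compound and lower numbers for a less stable compound), compound 3 `COc1cc(-c2cnn3cc(OC)c(C)nc23)ccn1` gives 44%, the second highest of the three numbers so far. Compound 1 `COc1cc(-c2cnn3cc(OC)c(C4CCOC4)nc23)ccn1` gives 29%, and compound 2 `COc1cc(-c2cnn3cc(OC)c(C(C)(C)O)nc23)ccn1` gives 66% in this assay. The steps show this position matters: a number 15 percentage points higher from compound 1 to compound 3 (beyond the scatter), a number 37 percentage points higher from compound 1 to compound 2 (beyond the scatter), and a number 22 percentage points lower from compound 2 to compound 3 (beyond the scatter).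

Compound 4 `CNc1nc2c(-c3ccnc(OC)c3)cnn2cc1OC` differs from compound 3 by methylamino in place of methyl on an aromatic carbon. For the measured compounds named here, no measured step covers methylamino at this position. The nearest comparison is compound 2, where a group carrying a hydrogen-bond donor and acceptor stands at the same place and gives the highest number of the series, while the two groups without a donor, in compound 1 and compound 3, lie lower. On that basis a modest rise is expected, smaller than the step to compound 2, since methylamino is not the same group. Compound 4 is therefore estimated at 52% in this assay, with a range from 30% to 74%. The expected step is a number 8 percentage points higher from compound 3 to compound 4 (within the scatter).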

Compound 4, percent of the compound remaining: 63%
Compound 4: the middle estimate sits 11 percentage points below what was measured; low and high end bracket the measured number.
By their numbers in this assay, from the lowest: compound 1; then compound 3; then compounds 4 and 2 (each within the scatter of the next).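

In this assay, methylamino gives a clear rise over methyl (a number 19 percentage points higher from compound 3 to compound 4 (beyond the scatter)) and a reading that cannot be told apart from that of 1-hydroxy-1-methylethyl (a number 3 percentage points lower from compound 2 to compound 4 (within the scatter)), so a high number at this position does not belong to 1-hydroxy-1-methylethyl alone. Methylamino also stands well clear of oxolan-3-yl (a number 34 percentage points higher from compound 1 to compound 4 (beyond the scatter)), and across these four compounds the two groups carrying a hydrogen-bond donor, in compound 2 and compound 4, both lie above the two groups without one, in compound 1 and compound 3, with no compound going against this split. That split is only an observation on four compounds, and nothing available here explains the change in the number.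

The compounds shown leave open whether the donor or the nitrogen goes with the higher number, a question that the plain amino group and dimethylamino at the same position would help to separate. They also leave open how far the trend extends to a longer chain on the nitrogen, such as ethylamino, or to a hydroxymethyl group.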